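Cyclobutyl for Cyclopropyl on the Amide of Compound 1

The source may report more compounds than this note shows. Statements on the series, on what has been measured and on what is new or still open speak of the compounds shown alone.

Going by the values given here, compound 1 `C[C@@H]1CN(c2nc(-c3cnn(C)c3)ncc2C#N)CCN1C(=O)C1CC1` is the one compound here with a number rather than a limit in an ADME assay on microsomes from liver (Homo sapiens) for pharmacokinetics (a higher number here means faster removal of the compound, a lower number slower removal), where compound 1 gives 21 mL/min/kg. Two relatives share its nitrile-bearing core but carry a bridged bicyclic amine instead of the methylpiperazine. Compound 2 `Cn1cc(-c2ncc(C#N)c(N3C[C@@H]4C[C@H]3CN4CC3CC3)n2)cn1` in this assay returns only a limit, < 16 mL/min/kg. Compound 3 `Cn1cc(-c2ncc(C#N)c(N3C[C@@H]4C[C@H]3CN4C(=O)C3CC3)n2)cn1` likewise returns only a limit in this assay, < 16 mL/min/kg. Among the compounds with values here, the single step between measured compounds, a step that the two limits leave unreadable from compound 2 to compound 3, therefore cannot be sized, since both ends sit at the limit of < 16 mL/min/kg in this assay, at which 2 of the 3 values shown sit.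

Compound 4 `C[C@@H]1CN(c2nc(-c3cnn(C)c3)ncc2C#N)CCN1C(=O)C1CCC1` differs from compound 1 by cyclobutyl in place of cyclopropyl on a carbonyl carbon. Within the data shown here, no measured step alters this part of the molecule: the step from compound 2 to compound 3 exchanges a carbonyl for a methylene on the amine nitrogen, not the ring on the carbonyl carbon, and it is unreadable anyway. With nothing pointing to a large shift, the change is expected to stay within the usual scatter, giving an expected step of a 1.2-fold higher number from compound 1 to compound 4 (0.08 log units; within the scatter). Compound 4 is thus estimated at 25 mL/min/kg in this assay, with a likely range from 13 mL/min/kg to 50 mL/min/kg.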

Compound 4, clearance: < 16 mL/min/kg
Compound 4: only a limit was reported (the forecaster's own chance of this, stated with the estimate: 20%); middle value at least 1.5-fold (0.19 log units) from the limit.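

Going by these compounds alone, this is the first readable step at the ring on the carbonyl carbon, and in this assay it reads an at least 1.3-fold lower number from compound 1 to compound 4 (0.11 log units; that floor lies within the scatter) and so gives a floor, not a full size. Within the data shown here, that floor does not establish a real difference between the two rings, but it does show that cyclobutyl in place of cyclopropyl at this place brings no rise in the clearance read-out, something the earlier compounds could not show, since none of them changes this ring. Only a floor can be given because compound 4 now stands at the same limit as compound 2 and compound 3, so the assay no longer separates them: the limit of < 16 mL/min/kg in this assay, at which 3 of the 4 values shown sit.

From the compounds shown here alone, how far under that limit compound 4 truly lies stays open, and so does whether the same change would behave alike on the bridged bicyclic amine of compound 3. Also open, going by these compounds, is what a cyclopentyl ring, a longer chain such as butyl, or a cyclobutyl ring carrying an amine would do on this carbonyl carbon, and whether any of them would return a number rather than a limit.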